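Swapping phenylsulfanyl for 1-benzothiophen-2-yl

This account rests on a few compounds, and the source may have more. Where it says the series, first, only, none or still open, it means among the compounds named here.

In an ADME assay on MDCK cells (Canis lupus familiaris) for cytotoxicity, read by MTT assay, with a stated time of 48 h (on this read-out higher numbers stand for lower toxicity in this test and lower numbers for higher toxicity in this test), compound 1 (`CCC(CC)O[C@@H]1C=C(C(=O)O)C[C@H](NCc2ccc(Sc3cccs3)cc2)[C@H]1NC(C)=O`) gives > 250000 nM and this is a limit of the assay. Compound 2 (`CCC(CC)O[C@@H]1C=C(C(=O)O)C[C@H](NCc2ccc(Sc3ccccc3)cc2)[C@H]1NC(C)=O`) gives > 250000 nM and this too is a limit, so it has no exact number. For the measured compounds named here, both compounds rest at the limit of > 250000 nM in this assay, at which 2 of the 2 values shown sit, and the only measured step is a step that the two limits leave unreadable from compound 1 to compound 2 and offers no size to carry over. Compound 3 (`CCC(CC)O[C@@H]1C=C(C(=O)O)C[C@H](NCc2ccc(-c3cc4ccccc4s3)cc2)[C@H]1NC(C)=O`) differs from compound 2 by 1-benzothiophen-2-yl in place of phenylsulfanyl on an aromatic carbon with 1-benzothiophen-2-yl in place of phenylsulfanyl on an aromatic carbon. The expected step is a number no higher from compound 2 to compound 3 (the limit leaves the size open) and nothing beyond the scatter is foreseen in this assay in either direction. Compound 3 is estimated at 250000 nM with an expected range of 120000 nM to 500000 nM and a limit is the likely report.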

Compound 3, half-maximal cytotoxic concentration: > 250000 nM
Compound 3: no number, only a limit; the forecaster's own chance of this, stated with the estimate: 85%; the middle value sits exactly at the limit.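

Compound 3, like compound 1 and compound 2, is reported only as a limit, so no step among them can be read in this assay: the limit of > 250000 nM in this assay, at which 3 of the 3 values shown sit.

On these data alone, whether these three compounds differ at all in half-maximal cytotoxic concentration remains open.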